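A Carbamate Aryl Swap Followed into Unmeasured Ground

This account rests on a few compounds, and the source may have more. Where it says the series, first, only, none or still open, it means among the compounds named here.

Compound 1 `COc1ccccc1NC(=O)Oc1cc(=O)n(CCCO)c2c1CC(C/C=C(\C)CCC=C(C)C)C(C)(C)C2`: 53%
Compound 2 `CC(C)=CCC/C(C)=C/CC1Cc2c(OC(=O)Nc3ccc(F)c(Cl)c3)cc(=O)n(CCCO)c2CC1(C)C`: 25%

Of the compounds shown here, two on a shared core have been measured in a functional assay on PANC-1 cells (Homo sapiens) for inhibition, read by MTT assay, with a stated time of 24 h, tested at 10 uM; on this read-out lower numbers stand for less inhibition and higher numbers for more inhibition at the one concentration tested (going by the name of the read-out). In this assay compound 1 gives 53%, while compound 2 gives 25%. Among the measured compounds shown here, the one step between them, a number 28 percentage points lower from compound 1 to compound 2 (beyond the scatter), puts 3-chloro-4-fluorophenyl in place of 2-methoxyphenyl on the amide-type nitrogen. Compound 2 therefore stands lowest of the two numbers, with compound 1 as its nearest neighbour beyond the scatter.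

Compound 3 `CC(C)=CCC/C(C)=C/CC1Cc2c(OC(=O)Nc3ccc(Cl)cc3)cc(=O)n(CCCO)c2CC1(C)C` differs from compound 2 only at that aryl group: 4-chlorophenyl in place of 3-chloro-4-fluorophenyl on an amide-type nitrogen. For the measured compounds named here, no measured step changes one halogenated phenyl for another, so the single step of a number 28 percentage points lower from compound 1 to compound 2 (beyond the scatter) bears on it only loosely, as a sign that the aryl group can move this read-out by a modest amount. Compound 3 is expected to land near compound 2, with a small rise possible but nothing assured, so the step of a number 8 percentage points higher from compound 2 to compound 3 (within the scatter) is estimated as small and uncertain in direction. Compound 3 is estimated at 33%, within 12% to 56%.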

Compound 3, a percentage reported as inhibition, at one concentration (the size of the read-out at that concentration, not a potency): 47.2%
The estimate for compound 3 lay 14.2 percentage points below the measured number, within the range that was stated.
By their numbers in this assay, from the lowest: compound 2; then compounds 3 and 1 (each within the scatter of the next).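

In this assay, 4-chlorophenyl in place of 3-chloro-4-fluorophenyl on the amide-type nitrogen gives a number 22.2 percentage points higher from compound 2 to compound 3 (beyond the scatter), so a change confined to the halogens on this phenyl ring is enough to move the number beyond the scatter. The earlier step alone left room to read a halogenated phenyl as such as the mark of a low number, but the step of a number 5.8 percentage points lower from compound 1 to compound 3 (within the scatter) puts a chlorinated phenyl within the scatter of 2-methoxyphenyl, and among these three compounds only compound 2, with 3-chloro-4-fluorophenyl, stands apart. No supporting data are available to explain why these aryl groups differ in this way.

The compounds shown leave open whether the low number of compound 2 goes with the chlorine in the 3-chloro arrangement, with the fluorine, or only with the two together, a question that 3-chlorophenyl and 4-fluorophenyl on the same nitrogen would address. They also leave open how this position responds to a group other than a substituted phenyl, such as a benzyl group or a pyridyl ring, and whether these differences hold at other concentrations.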